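The source may hold more compounds than are shown below. What is called first, only, known or untested is meant among the compounds shown, and "the series" means these compounds.

Measured in an ADME assay on RAW264.7 cells (Mus musculus) for cytotoxicity, read by MTT assay, with a stated time of 24 h, in the absence of a further agent; on this read-out higher numbers stand for weaker inhibition and lower numbers for stronger inhibition:
- compound 1 `O=C1OC(Cc2nc(-c3ccccc3)no2)c2ccccc21`: > 40000 nM
- compound 2 `O=C1OC(Cc2nc(-c3ccc(Oc4ccccc4)cc3)no2)c2ccccc21`: > 40000 nM
- compound 3 `CCC(C)Oc1ccc(C(O)C2OC(=O)c3c(OC)cc(OC)cc32)cc1`: > 40000 nM

Among the compounds with values here, none of these readings is an exact number, and the series so far shows (the limit of > 40000 nM in this assay, at which 3 of the 3 values shown sit). Compound 3 gives > 40000 nM, and this is a limit. It therefore shares its place with the other two compounds, and no order can be read among them.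

Compound 4 `COc1cc(OC)c2c(c1)C(C(O)c1ccc(OCc3ccc(F)cc3)cc1)OC2=O` has 4-fluorobenzyl in place of sec-butyl on an oxygen on an aromatic ring. The enlarged group brings in a six-membered aromatic ring.

Within the data shown here, the one measured step that bears on this change is a step that the two limits leave unreadable from compound 1 to compound 2. It lies on a different core, and its size cannot be read. It gives no sign of a change, so no step beyond the scatter is expected in this assay, though this is weak evidence. The expected step is a number no higher from compound 3 to compound 4 (the limit leaves the size open). The estimate for compound 4 is 40000 nM, with an expected range from 20000 nM to 80000 nM.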

Compound 4, half-maximal inhibitory concentration: > 40000 nM
Compound 4 ended at the assay's limit (the forecaster's own chance of this, stated with the estimate: 75%); the middle value sits exactly at the limit.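

The readings of compound 3 and compound 4 are both limits and not numbers, so no step can be read between them: the limit of > 40000 nM in this assay, at which 4 of the 4 values shown sit. Left open is what concentration of any of these compounds would harm the cells, and whether 4-fluorobenzyl in place of sec-butyl changes that concentration.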